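Methoxy for Chloro on a Second Core: Cytotoxicity Expectation

The source may hold more compounds than are shown below. What is called first, only, known or untested is meant among the compounds shown, and "the series" means these compounds.

Measured compounds:
compound 1, `O=C(CN1CCN(C(=O)c2ccc(Cl)cc2)CC1)N1CCN(CCCc2c[nH]c3ccccc23)CC1`, 139000 nM
compound 2, `COc1ccc(C(=O)N2CCN(CC(=O)N3CCN(CCCc4c[nH]c5ccccc45)CC3)CC2)cc1`, 148000 nM
compound 3, `O=C(CN1CCN(C(=O)c2cccc(Cl)c2)CC1)N1CCN(CCCc2c[nH]c3ccc(F)cc23)CC1`, 59800 nM

Of the compounds shown here, three have been tested in an ADME assay on SH-SY5Y cells (Homo sapiens) for cytotoxicity, read by MTT assay, with a stated time of 72 h; on this read-out lower numbers stand for stronger inhibition and higher numbers for weaker inhibition. Compound 1 and compound 2 share a core; compound 2 differs from it by methoxy in place of chloro on an aromatic carbon, and that change gave a 1.1-fold higher number from compound 1 to compound 2 (0.03 log units; within the scatter). Compound 3 sits on a different core; the difference between the two cores is not broken down here. In this assay compound 3 gives the lowest of the three numbers, with compound 1 and compound 2 both standing beyond the scatter above it.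

Compound 4, `COc1cccc(C(=O)N2CCN(CC(=O)N3CCN(CCCc4c[nH]c5ccc(F)cc45)CC3)CC2)c1`, is not yet measured. It differs from compound 3 by methoxy in place of chloro on an aromatic carbon. This is the same kind of change as that from compound 1 to compound 2, though not the same: in the earlier pair the group sits para to a large group, here it sits meta to a large group.

The step from compound 3 to compound 4 is estimated as a 1.1-fold higher number from compound 3 to compound 4 (0.04 log units; within the scatter), resting on the earlier pair, in which compound 1 gave 139000 nM and compound 2 gave 148000 nM, a step within the scatter. The expected value for compound 4 in this assay is 65000 nM, between 30000 nM and 130000 nM.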

Compound 4, half-maximal inhibitory concentration: 79400 nM
Beside the measured number, compound 4's estimate is 1.2-fold (0.09 log units) below it; low and high end bracket the measured number.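

In this assay, the swap from 3-chlorophenyl to 3-methoxyphenyl gave a 1.3-fold higher number from compound 3 to compound 4 (0.12 log units; within the scatter). Set beside the earlier pair, the change carries over from one core to the other without a detectable difference: the same change on two cores in this assay, a 1.1-fold higher number (0.03 log units; within the scatter) from compound 1 to compound 2 and a 1.3-fold higher number (0.12 log units; within the scatter) from compound 3 to compound 4, 1.2-fold (0.10 log units) apart, within the scatter of two such steps. This shows only that methoxy and chloro stay within the scatter of each other on these two cores; it does not show that the same would hold on a further core, and since the two pairs differ both in core and in where the group sits on the ring, the contribution of either difference cannot be separated.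

The compounds shown leave open whether a group of another kind in this place, such as an amine, a carboxylic acid or a longer chain like ethoxy, would move the number beyond the scatter. They also leave open whether methoxy for chloro would stay as small a step with the core of compound 1 and the group meta to a large group.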